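Adding a phenyl to compound 3

A few compounds are considered here, and "the series" means these few. Any claim that something is new, unique, unknown or untested is made for them only; others in the source may bear on it.

Measured in an ADME assay on J774.1 cells (Mus musculus) for cytotoxicity, read by resazurin assay, with a stated time of 48 h; on this read-out lower numbers stand for stronger inhibition and higher numbers for weaker inhibition:
compound 1 `CCCCn1cc(C(=O)O)c(=O)c2cc(F)c(Cl)cc21`: > 100000 nM
compound 2 `CCCCn1cc(C(=O)O)c(=O)c2cc(F)c(N3CCC(C(N)=O)CC3)cc21`: > 100000 nM
compound 3 `CCCCn1cc(C(=O)O)c(=O)c2cc(F)c(N(C)C)cc21`: > 100000 nM

All three compounds sit at the same point: the limit of > 100000 nM in this assay, at which 3 of the 3 values shown sit. Compound 3 therefore has no exact number, and its > 100000 nM is a limit of the assay.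

Compound 4 `CCCCn1cc(C(=O)O)c(=O)c2cc(F)c(N(C)Cc3ccccc3)cc21` carries one change: phenyl in place of hydrogen on a saturated chain carbon bound to a nitrogen on an aromatic ring. This is phenyl in place of hydrogen on a saturated chain carbon bound to a nitrogen on an aromatic ring, which turns dimethylamino into benzyl(methyl)amino.

The nearest measured changes are swaps of the group on an aromatic carbon: a step that the two limits leave unreadable from compound 1 to compound 3, a step that the two limits leave unreadable from compound 2 to compound 3 and a step that the two limits leave unreadable from compound 1 to compound 2. None of them has a readable size, so they offer no direction for the new change. They include a large 4-carbamoylpiperidin-1-yl group, and compound 2 still gives only a limit.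

In this assay, no step beyond the scatter is therefore expected, and the estimated change is a number no higher from compound 3 to compound 4 (the limit leaves the size open). For compound 4 the estimate is 100000 nM, with an expected range from 40000 nM to 200000 nM.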

Compound 4, half-maximal inhibitory concentration: 43200 nM
The estimate for compound 4 lay 2.3-fold (0.36 log units) above the measured number; low and high end bracket the measured number.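

In this assay, going by these compounds alone, the phenyl on the saturated chain carbon bound to the nitrogen gives the first step in this set with a readable direction: an at least 2.3-fold lower number from compound 3 to compound 4 (0.36 log units; beyond the scatter). The group on the aromatic carbon can therefore shift this read-out, as seen in an at least 2.3-fold lower number from compound 2 to compound 4 (0.36 log units; beyond the scatter) and in an at least 2.3-fold lower number from compound 1 to compound 4 (0.36 log units; beyond the scatter), whereas the steps among the three earlier compounds cannot be read. Compound 4 is the only compound here with an exact number, and each of these steps has only a minimum size, as the other values are limits: the limit of > 100000 nM in this assay, at which 3 of the 4 values shown sit.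

Going by these compounds, the full size of all three steps remains open. So does whether a longer chain on that nitrogen, such as phenethyl, or an amine or a hydroxyl on the new phenyl ring would move the number further.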